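Removing the methoxymethyl group from compound 1

A few compounds are considered here, and "the series" means these few. Any claim that something is new, unique, unknown or untested is made for them only; others in the source may bear on it.

Compound 1 `COCOc1cc(/C=C/C(=O)OCC(=O)Nc2ccc(OC)cc2)ccc1OCc1ccccc1` is measured in a functional assay on HL-60 cells (Homo sapiens) for cytotoxicity, read by MTT assay, with a stated time of 72 h (on this read-out lower numbers stand for stronger inhibition and higher numbers for weaker inhibition), only as a limit, > 200000 nM, and gives no number. Compound 2 `COCOc1cc(/C=C/C(=O)OCC(=O)Nc2ccc(Cl)cc2)ccc1OCc1ccccc1` likewise sits at a limit of this assay, > 200000 nM. Compound 3 `COCOc1cc(/C=C/C(=O)OCC(=O)NN2CCOCC2)ccc1OCc1ccccc1` is the only one of the three with a number in this assay, 50400 nM. The step of an at least 3.9-fold lower number from compound 1 to compound 3 (0.59 log units; beyond the scatter) and the step of an at least 3.9-fold lower number from compound 2 to compound 3 (0.59 log units; beyond the scatter) are both readable, whereas the step that the two limits leave unreadable from compound 1 to compound 2 is not, as the shared limit of > 200000 nM in this assay, at which 2 of the 3 values shown sit, shows. Compound 4 `COc1ccc(NC(=O)COC(=O)/C=C/c2ccc(OCc3ccccc3)c(O)c2)cc1` differs from compound 1 by hydrogen in place of methoxymethyl on an oxygen on an aromatic ring. Going by the values given here, none of the measured steps touches the methoxymethyl group: the readable ones concern the amide nitrogen and the unreadable one the aromatic substituent, so no measured step bears directly on this change. With compound 1 at a limit, the direction and size of the step are open, and a value anywhere from the limit downward is possible. Compound 4 is therefore expected to stand at about 150000 nM in this assay, within 30000 nM to 400000 nM, meaning an estimated step of an at least 1.3-fold lower number from compound 1 to compound 4 (0.12 log units; that floor lies within the scatter).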

Compound 4, half-maximal inhibitory concentration: > 200000 nM
Compound 4: a limit, no number (the forecaster's own chance of this, stated with the estimate: 55%); middle value at least 1.3-fold (0.12 log units) away from the limit.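

Compound 4, like compound 1, gives only a limit in this assay, and the step between these two compounds cannot be read: the limit of > 200000 nM in this assay, at which 3 of the 4 values shown sit. On these data alone, whether hydroxy in place of methoxymethoxy changes the read-out at all, and in which direction, remains open.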